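The source may report more compounds than this note shows. Statements on the series, on what has been measured and on what is new or still open speak of the compounds shown alone.

Compound 1 `O=C(Nc1ccccc1)Nc1cccc(CNc2nccnc2Cl)c1` gives 19800 nM in a functional assay on T-24 cells (Homo sapiens) for antiproliferative activity, read by MTT assay, with a stated time of 48 h; on this read-out higher numbers stand for weaker inhibition and lower numbers for stronger inhibition. Compound 2 `CN(C)c1ccc(NC(=O)Nc2cccc(CNc3nccnc3Cl)c2)cc1` gives 20200 nM. Compound 3 `O=C(Nc1cccc(CNc2nccnc2Cl)c1)Nc1ccc(Cl)cc1Cl` gives 5740 nM.

Compound 1 stands second highest of the three numbers: the gap to compound 2 is a 1.0-fold higher number from compound 1 to compound 2 (0.01 log units; within the scatter), while the gap to compound 3 is a 3.4-fold lower number from compound 1 to compound 3 (0.54 log units; beyond the scatter). Compound 4 `O=C(Nc1cccc(CNc2nccnc2Cl)c1)Nc1ccccc1F` differs from compound 1 by fluoro in place of hydrogen on an aromatic carbon. Among the compounds with values here, the closest precedent is the step from compound 1 to compound 3, where 2,4-dichlorophenyl in place of phenyl on an amide-type nitrogen gave a modest lowering; a single fluoro is a smaller change, so a step no larger than that, and possibly none beyond the scatter, is expected. Compound 4 is therefore estimated at 14000 nM (range 7000 nM to 28000 nM), an expected step of a 1.4-fold lower number from compound 1 to compound 4 (0.15 log units; within the scatter).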

Compound 4, half-maximal inhibitory concentration: 7450 nM
Compound 4: the middle estimate sits 1.9-fold (0.27 log units) above what was measured; measured number inside the range.
By their numbers in this assay, from the lowest: compounds 3 and 4 (each within the scatter of the next); then compounds 1 and 2 (each within the scatter of the next).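

A single fluoro on the aromatic ring, ortho to a large group, is enough to shift the number (a 2.7-fold lower number from compound 1 to compound 4 (0.42 log units; beyond the scatter)). With that one atom, the compound also sits level with the 2,4-dichlorophenyl compound (a 1.3-fold higher number from compound 3 to compound 4 (0.11 log units; within the scatter)), while the 2-fluorophenyl group gives a lower number than 4-(dimethylamino)phenyl (a 2.7-fold lower number from compound 2 to compound 4 (0.43 log units; beyond the scatter)), so two chlorines are not required for a lower number. Nothing available here explains why the fluoro has this effect.

As far as these compounds go, it remains open whether a methyl, methoxy or nitrile at the same place would lower the number too, and whether fluoro elsewhere on the ring would match it.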